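The source may report more compounds than this note shows. Statements on the series, on what has been measured and on what is new or still open speak of the compounds shown alone.

Measured compounds

Compound 1 `Cc1ccc(-c2cc(C)cc(C(=O)Nc3nn[nH]n3)n2)cc1`: in a functional assay on the whole organism with Rattus norvegicus as the target, at a dose of 3 mg/kg by the oral route (a higher number here means a stronger effect of the compound at the dose given, a lower number a weaker effect), compound 1 gives 100%.
Compound 2 `Cc1cc(C(=O)Nc2nn[nH]n2)nc(-c2ccc(C(C)C)cc2)c1`: in this assay compound 2 gives 100%.

Where compound 2 stands: it is level with compound 1 at the digits given, and compound 1 is the only other measured member of the series. Among the compounds with values here, the one measured step, no change at the digits printed from compound 1 to compound 2 (within the scatter), lies within the scatter.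

The next compound is compound 3 `CCCCc1ccc(-c2cc(C)cc(C(=O)Nc3nn[nH]n3)n2)cc1`. It differs from compound 2 at a single place: butyl in place of isopropyl on an aromatic carbon.

Bearing on this step: only the step from compound 1 to compound 2 is comparable, an exchange of methyl for isopropyl on the same aromatic carbon, and it came out as no change at the digits printed from compound 1 to compound 2 (within the scatter). The change to compound 3 is of the same kind, butyl in place of isopropyl at that carbon. On this basis no step beyond the scatter is expected in this assay. Since compound 2 already gives 100%, the read-out cannot register a rise, so any movement expected would be a slight fall at most.

Compound 3 is therefore estimated at 96%, with a range of 82% to 100%. This estimate means an expected step of a number 4 percentage points lower from compound 2 to compound 3 (within the scatter), within the scatter.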

Compound 3, a percentage reported as inhibition, in the whole organism at one dose (the size of the read-out at that dose, not a potency): 67%
Compound 3: middle estimate off by 29 percentage points, on the high side; measured number outside the range, below it.
By their numbers in this assay, from the lowest: compound 3; then compounds 1 and 2 (each within the scatter of the next).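

In this assay, the aromatic carbon para to a large group is not indifferent to the alkyl group it carries: butyl in place of isopropyl gives a number 33 percentage points lower from compound 2 to compound 3 (beyond the scatter), and propyl in place of hydrogen on the saturated chain carbon bound to the aromatic carbon gives a number 33 percentage points lower from compound 1 to compound 3 (beyond the scatter). The earlier exchange of methyl for isopropyl gave no change at the digits printed from compound 1 to compound 2 (within the scatter), so the tolerance seen there does not extend to butyl. Nothing available bears on the reason for this loss.

Still open, from the compounds shown here alone, is whether the loss follows the length of the chain or its unbranched shape, a question that propyl, tert-butyl or a longer chain such as pentyl at this carbon would help to settle. Going by these compounds, compound 1 and compound 2 also stand level at a single dose, so any difference between methyl and isopropyl at lower doses remains unknown, as does the behaviour of an ether or an amine at this carbon.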